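The compounds below may be only part of what the source reports. "The series", "measured", "known", "first", "only" and "open" are said of these compounds alone.

Measured in an ADME assay on RAW264.7 cells (Mus musculus) for cytotoxicity, read by MTT assay, with a stated time of 24 h, in the presence of a further agent that is not named here; on this read-out higher numbers stand for weaker inhibition and lower numbers for stronger inhibition:
- Compound 1 `CCCCOc1ccc(C(O)C2OC(=O)c3c(OC)cc(OC)cc32)cc1`: > 40000 nM, a limit.
- Compound 2 `CCOCCOc1ccc(C(O)C2OC(=O)c3c(OC)cc(OC)cc32)cc1`: > 40000 nM, a limit.

Compound 2 therefore has no numerical position in the series. Its entry is a limit and not a number, and the only other entry shown is also a limit.

Compound 3 `COc1cc(OC)c2c(c1)C(C(O)c1ccc(OCc3ccccc3)cc1)OC2=O` carries benzyloxy where compound 2 carries 2-ethoxyethoxy: phenyl in place of ethoxymethyl on a saturated chain carbon bound to an oxygen on an aromatic ring. The change is phenyl in place of ethoxymethyl on a saturated chain carbon bound to an oxygen on an aromatic ring.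

For the measured compounds named here, only one measured step bears on this change: a step that the two limits leave unreadable from compound 1 to compound 2. That step also alters the chain on the oxygen on the aromatic ring, but it gives no size to carry forward.

No step beyond the scatter is expected in this assay, and no direction can be assigned, because the limit of > 40000 nM in this assay, at which 2 of the 2 values shown sit, covers compound 1 and compound 2 alike. A report of compound 3 as a limit again is the likeliest outcome.

The expected step is a number no higher from compound 2 to compound 3 (the limit leaves the size open).

The estimate for compound 3 is 40000 nM, with an expected range from 20000 nM to 80000 nM.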

Compound 3, half-maximal inhibitory concentration: > 40000 nM
Compound 3: only a limit was reported; the forecaster's own chance of this, stated with the estimate: 75%; the middle value lies on the limit itself.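

No step can be read among compound 1, compound 2 and compound 3 in this assay, because all three entries are limits and not numbers: the limit of > 40000 nM in this assay, at which 3 of the 3 values shown sit.

The compounds shown leave open how butoxy, 2-ethoxyethoxy and benzyloxy rank against one another in this assay, and whether any chain at this place on the shared core gives a numerical value.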